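Pyrimidin-2-yl in place of pyridazin-3-yl: notes on compound 3

This account rests on a few compounds, and the source may have more. Where it says the series, first, only, none or still open, it means among the compounds named here.

Measured in a physicochemical assay for solubility, in phosphate buffer, with a stated time of 2 h, at pH 7.4; a lower number here means a less soluble compound, a higher number a more soluble compound:
- compound 1 `Clc1ccc(Nc2nc(-c3cccnn3)cs2)nc1`: 20000 nM
- compound 2 `Clc1ccc(Nc2nc(-c3cccnn3)c(Cl)s2)nc1`: < 10000 nM (a limit, not a number)

Compound 2 has no number, only (the limit of < 10000 nM in this assay, at which 1 of the 2 values shown sits). The next compound, compound 3 `Clc1ccc(Nc2nc(-c3ncccn3)c(Cl)s2)nc1`, has the same atoms joined differently: pyrimidin-2-yl in place of pyridazin-3-yl on an aromatic carbon. In words, pyrimidin-2-yl stands in place of pyridazin-3-yl on an aromatic carbon.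

Among the measured compounds shown here, the only measured step, an at least 2.0-fold lower number from compound 1 to compound 2 (0.30 log units; that floor lies within the scatter), is a different change, chloro in place of hydrogen on an aromatic carbon, and compound 3 keeps that chloro group. For the measured compounds named here, no measured step covers this exchange of rings, so no change beyond the scatter is expected. The estimated step is a step that the limit leaves unreadable from compound 2 to compound 3 and it carries no expected direction of its own. In this assay the estimated value for compound 3 is 7000 nM with an expected range from 2000 nM to 20000 nM around it.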

Compound 3, solubility: < 10000 nM
Compound 3 gave a limit, no number (the forecaster's own chance of this, stated with the estimate: 60%); the middle value does not contradict the limit.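

No step from compound 2 to compound 3 can be read in this assay, since each of the two carries a limit and not a number: the limit of < 10000 nM in this assay, at which 2 of the 3 values shown sit.

Still open, from the compounds shown here alone, are the size and direction of the exchange of pyridazin-3-yl for pyrimidin-2-yl, and the full size of the chloro step from compound 1 to compound 2.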